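Extending the acetamido group of compound 2

The compounds below may be only part of what the source reports. "The series", "measured", "known", "first", "only" and "open" are said of these compounds alone.

In a functional assay on MDA-MB-231 cells (Homo sapiens) for antiproliferative activity, read by MTT assay, with a stated time of 72 h (on this read-out higher numbers stand for weaker inhibition and lower numbers for stronger inhibition), compound 1 `O=C(Nc1ccc(-c2noc(-c3cccc(NS(=O)(=O)c4ccc(C(F)(F)F)cc4)c3)n2)c(Cl)c1)c1cccnc1` gives > 10000 nM, which is a limit of the assay and not a number. Going by the values given here, compound 2 `CC(=O)Nc1ccc(S(=O)(=O)Nc2cccc(-c3nc(-c4ccc(NC(=O)c5cccnc5)cc4Cl)no3)c2)cc1` gives 2500 nM, the only true number so far. Among the compounds with values here, the single measured step, an at least 4.0-fold lower number from compound 1 to compound 2 (0.60 log units; beyond the scatter), put acetamido in place of trifluoromethyl on an aromatic carbon, and it rests on (the limit of > 10000 nM in this assay, at which 1 of the 2 values shown sits). Within the data shown here, compound 3 `CCNC(=O)Nc1ccc(S(=O)(=O)Nc2cccc(-c3nc(-c4ccc(NC(=O)c5cccnc5)cc4Cl)no3)c2)cc1` carries ethylamino in place of methyl on a carbonyl carbon, ethylamino in place of methyl on a carbonyl carbon, a change that no measured step tests. The estimated step, a 1.3-fold lower number from compound 2 to compound 3 (0.10 log units; within the scatter), is expected to stay within the scatter. For compound 3 the expected value is 2000 nM, with an estimated range of 600 nM to 8000 nM.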

Compound 3, half-maximal inhibitory concentration: 3100 nM
For compound 3 the middle estimate is 1.6-fold (0.19 log units) below the measured one; measured number inside the range.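

In this assay, ethylamino in place of methyl on a carbonyl carbon (a 1.2-fold higher number from compound 2 to compound 3 (0.09 log units; within the scatter)) stays within the scatter, so compound 2 and compound 3 cannot be told apart and this position takes the larger group with no readable change. Replacing trifluoromethyl with (ethylcarbamoyl)amino (an at least 3.2-fold lower number from compound 1 to compound 3 (0.50 log units; beyond the scatter)) now gives a second step beyond the scatter alongside the acetamido one. That step starts from the value of compound 1, which is a limit of the assay and not a number: the limit of > 10000 nM in this assay, at which 1 of the 3 values shown sits. As far as these compounds go, whether a longer chain, an amine or a carboxylic acid on this carbonyl carbon would move the number beyond the scatter remains open.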